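Swapping the aryl group on compound 3: what to expect

This account rests on a few compounds, and the source may have more. Where it says the series, first, only, none or still open, it means among the compounds named here.

Measured compounds:
compound 1 `Brc1cn2ccnc2c(-c2ccc3ncn(C4CCCCC4)c3c2)n1` — 10%
compound 2 `c1cn2cc(-c3ccsc3)nc(-c3ccc4ncn(C5CCCCC5)c4c3)c2n1` — 6.29%
compound 3 `Brc1ccc(-c2cn3ccnc3c(-c3ccc4ncn(C5CCCCC5)c4c3)n2)cc1` — 24.4%

In a functional assay on SF-539 cells (Homo sapiens) for inhibition, read by sulforhodamine B assay, with a stated time of 48 h, tested at 10 uM (on this read-out lower numbers stand for less inhibition and higher numbers for more inhibition at the one concentration tested (going by the name of the read-out)), compound 3 gives 24.4%, the highest of the three numbers; compound 1 gives 10% and compound 2 gives 6.29%, and both steps from them to compound 3 lie beyond the scatter. Compound 4 `Fc1ccccc1-c1cn2ccnc2c(-c2ccc3ncn(C4CCCCC4)c3c2)n1` has not been measured. It differs from compound 3 in one place: 2-fluorophenyl in place of 4-bromophenyl on an aromatic carbon. Going by the values given here, the steps that bear on this position are a number 14.4 percentage points higher from compound 1 to compound 3 (beyond the scatter) and a number 18.1 percentage points higher from compound 2 to compound 3 (beyond the scatter), both modest rises when a 4-bromophenyl replaced a smaller group, whereas a number 3.7 percentage points lower from compound 1 to compound 2 (within the scatter) was within the scatter. Among the compounds with values here, no measured pair shows one phenyl ring exchanged for another, so the data give no direct guide to the size of this step. Compound 4 keeps an aryl group at this place, so it is expected to stay near compound 3, and the estimated step is a number 5.4 percentage points lower from compound 3 to compound 4 (within the scatter), a change that may well fall within the scatter. Compound 4 is therefore estimated at 19%, with a range from 6% to 34%.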

Compound 4, a percentage reported as inhibition, at one concentration (the size of the read-out at that concentration, not a potency): 4.51%
For compound 4 the middle estimate is 14.5 percentage points above the measured one, outside the stated range (below it).
By their numbers in this assay, from the lowest: compounds 4, 2 and 1 (each within the scatter of the next); then compound 3.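

In this assay an aryl group at this place proved not enough to hold the number up: the result is a number 19.9 percentage points lower from compound 3 to compound 4 (beyond the scatter) and shows that the rise seen with 4-bromophenyl does not carry over to 2-fluorophenyl. The new group instead reads level with the two other groups, with a number 1.8 percentage points lower from compound 2 to compound 4 (within the scatter) and a number 5.5 percentage points lower from compound 1 to compound 4 (within the scatter) as the remaining steps, so among these four compounds only 4-bromophenyl stands apart. Nothing at hand explains why two phenyl groups with the same count of heavy atoms part in this way.

The compounds shown leave open whether the halogen or its place on the phenyl ring carries this step, a question that 4-fluorophenyl and 2-bromophenyl would separate. As far as these compounds go, how an amine such as 4-aminophenyl would read at this place also remains open.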